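One more carbon on the ester chain of compound 2

The source may report more compounds than this note shows. Statements on the series, on what has been measured and on what is new or still open speak of the compounds shown alone.

Compound 1 `CC[C@](C)(O)CC(=O)O[C@H](CC=C(C)C)C1=CC(=O)c2c(O)ccc(O)c2C1=O` gives 20500 nM
Compound 2 `CCC(C)(O)CC(=O)O[C@H](CC=C(C)C)C1=CC(=O)c2c(O)ccc(O)c2C1=O` gives 16000 nM

In a functional assay on DU-145 cells (Homo sapiens) for cytotoxicity, read by MTT assay (on this read-out lower numbers stand for stronger inhibition and higher numbers for weaker inhibition), compound 1 gives 20500 nM and compound 2 gives 16000 nM in the same test. The gap between them is a 1.3-fold lower number from compound 1 to compound 2 (0.11 log units; within the scatter) and it lies within the scatter, so compound 2 stands level with compound 1.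

Compound 3 `CCC(O)(CC)CC(=O)O[C@H](CC=C(C)C)C1=CC(=O)c2c(O)ccc(O)c2C1=O` departs from compound 2 by methyl in place of hydrogen on a saturated chain carbon, two bonds along the chain from an oxygen on a saturated carbon and nothing else. Read one bond further out, this is methyl to ethyl, which turns 2-hydroxy-2-methylbutyl into 2-ethyl-2-hydroxybutyl.

For the measured compounds named here, no measured step covers a change of this kind. The only structural point behind the one available gap is the fact that one of compounds 1 and 2 is drawn with a defined configuration and the other without, at the place where they differ and it says nothing about a longer chain. With so little to go on, no step beyond the scatter is expected in this assay and neither direction is favoured, although the uncertainty is wide. The expected step is a 1.1-fold lower number from compound 2 to compound 3 (0.03 log units; within the scatter) and no more than that. For compound 3 the estimated value is 15000 nM with an expected range from 7000 nM to 32000 nM in this test.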

Compound 3, half-maximal inhibitory concentration: 67000 nM
Compound 3: middle estimate off by 4.5-fold (0.65 log units), on the low side; the measured number lies above the stated range.
By their numbers in this assay, from the lowest: compounds 2 and 1 (each within the scatter of the next); then compound 3.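

In this assay, the change from 2-hydroxy-2-methylbutyl to 2-ethyl-2-hydroxybutyl gives a 4.2-fold higher number from compound 2 to compound 3 (0.62 log units; beyond the scatter), and the comparison with the stereochemically defined compound gives the same picture, a 3.3-fold higher number from compound 1 to compound 3 (0.51 log units; beyond the scatter); both steps lie beyond the scatter, and since a higher number stands for weaker inhibition, this single added methyl costs a modest but real amount of activity. The earlier pair could not show this, since compounds 1 and 2 differ only in how one stereocentre is drawn and stand level with each other, so until now no change at this position had been seen to move the number. The information at hand bears on a drawn configuration and not on chain length, so it offers no explanation for the loss of activity on going to the ethyl group.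

The compounds shown leave open whether a propyl group or a longer chain at this position would lower activity further, or whether the loss stops at ethyl. They also leave open how the number would respond to an amine or a methoxy group in place of the hydroxy group on this chain.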